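From ester to urea on a weakly active biaryl

The compounds below may be only part of what the source reports. "The series", "measured", "known", "first", "only" and "open" are said of these compounds alone.

Compound 1 `CCOc1ccc(-c2ccccc2)cc1` and compound 2 `CCOc1ccc(-c2cccc(C(=O)O)c2)cc1` are the two compounds that give only a limit of the assay. In an assay on COS-7 cells for inhibition of patatin-like phospholipase domain-containing protein 2 (Mus musculus) (on this read-out higher numbers stand for weaker inhibition and lower numbers for stronger inhibition), compound 1 gives > 200000 nM, a limit. Compound 2 gives > 200000 nM, also a limit. Going by the values given here, compound 3 `CCOc1ccc(-c2cccc(C(=O)OCCOC)c2)cc1` gives 70000 nM, the only actual number among the three, because the other two sit at the limit of > 200000 nM in this assay, at which 2 of the 3 values shown sit. Compound 4 `CCOc1ccc(-c2cccc(NC(=O)N(C)C)c2)cc1` differs from compound 3 by (dimethylcarbamoyl)amino in place of (2-methoxyethoxy)carbonyl on an aromatic carbon. The steps touching that position are an at least 2.8-fold lower number from compound 1 to compound 3 (0.45 log units; beyond the scatter) and an at least 2.8-fold lower number from compound 2 to compound 3 (0.45 log units; beyond the scatter); both show the substituent there matters, but neither tells how a urea compares with the ester. Compound 4 is therefore expected to land near compound 3 or somewhat weaker, a 1.4-fold higher number from compound 3 to compound 4 (0.15 log units; within the scatter). The estimate for compound 4 is 100000 nM, ranging from 30000 nM to 200000 nM.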

Compound 4, half-maximal inhibitory concentration: 70000 nM
For compound 4 the middle estimate is 1.4-fold (0.15 log units) above the measured one; measured number inside the range.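

In this assay, (dimethylcarbamoyl)amino in place of (2-methoxyethoxy)carbonyl gives no change at the digits printed from compound 3 to compound 4 (within the scatter), so at this position the urea and the ester cannot be told apart. Going by these compounds alone, the urea also gives an at least 2.8-fold lower number from compound 2 to compound 4 (0.45 log units; beyond the scatter) and an at least 2.8-fold lower number from compound 1 to compound 4 (0.45 log units; beyond the scatter), so the ester is no longer the only group here to show a readable gain over carboxy or hydrogen. Both of these steps are open-ended: the limit of > 200000 nM in this assay, at which 2 of the 4 values shown sit.

Still open, from the compounds shown here alone, is whether a simple amine or a longer chain on the urea at this position would lower the number further.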